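The source may report more compounds than this note shows. Statements on the series, on what has been measured and on what is new or still open speak of the compounds shown alone.

In an ADME assay on a cell-free system (plasma, Mus musculus) for protein binding, using equilibrium dialysis, with a stated time of 24 h (a lower number here means a smaller unbound share, a higher number a larger unbound share of the compound), compound 1 (`COc1nn(-c2ccccn2)c2cc(-c3ccc([C@H]4C[C@@H]4C(=O)O)cc3)cc(F)c12`) gives 0.0053 and compound 2 (`COc1nn(-c2ccccn2)c2cc(-c3ccc([C@H]4C[C@@H]4C(=O)O)cc3)ccc12`) gives 0.0048, so the two stand level. Compound 3 (`COc1nn(-c2ccc(C)cc2)c2cc(-c3ccc([C@H]4C[C@@H]4C(=O)O)cc3)cc(F)c12`) differs from compound 1 on an aromatic nitrogen: 4-methylphenyl in place of pyridin-2-yl on an aromatic nitrogen. Within the data shown here, the only measured step, a 1.1-fold lower number from compound 1 to compound 2 (0.04 log units; within the scatter), is hydrogen in place of fluoro on an aromatic carbon, so it does not test this group directly. The data therefore give only weak guidance, and a modest move to a lower number is expected in this assay, estimated as a 1.8-fold lower number from compound 1 to compound 3 (0.25 log units; within the scatter). For compound 3 the expected value is 0.003, with an estimated range from 0.0012 to 0.0065.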

Compound 3, unbound fraction: 0.0011
Compound 3: middle estimate off by 2.7-fold (0.44 log units), on the high side; measured number outside the range, below it.
By their numbers in this assay, from the lowest: compound 3; then compounds 2 and 1 (each within the scatter of the next).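

In this assay, the group on the aromatic nitrogen proves to matter: 4-methylphenyl in place of pyridin-2-yl gives a 4.8-fold lower number from compound 1 to compound 3 (0.68 log units; beyond the scatter). This step lies beyond the scatter, whereas the earlier change from fluoro to hydrogen on an aromatic carbon, a 1.1-fold lower number from compound 1 to compound 2 (0.04 log units; within the scatter), stayed within it. No measurement shown here accounts for the step.

On these data alone, it remains open whether a plain phenyl group at this nitrogen would stand with compound 1 or with compound 3, which would separate the loss of the ring nitrogen from the gain of the methyl group. As far as these compounds go, how an amine on this ring would behave also remains open.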